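The source may hold more compounds than are shown below. What is called first, only, known or untested is meant among the compounds shown, and "the series" means these compounds.

Measured in a functional assay on T-24 cells (Homo sapiens) for cytotoxicity, read by colorimetric assay and MTT assay; on this read-out higher numbers stand for weaker inhibition and lower numbers for stronger inhibition:
- Compound 1 `CCOC(=O)Cn1c(=O)c(-c2ccc(OC)cc2)cc2c(OC)cc(OC)cc21`: 10000 nM
- Compound 2 `COc1ccc(-c2cc3c(OC)cc(OC)cc3n(CC#N)c2=O)cc1`: 10000 nM
- Compound 3 `COc1ccc(-c2cc3c(OC)cc(OC)cc3n(CCCC#N)c2=O)cc1`: 10000 nM

Compound 3 stands level with compound 1 and compound 2, and all three share the same value, with compound 3 at 10000 nM. Compound 4 `COc1ccc(-c2cc3c(OC)cc(OC)cc3n(CC(=O)O)c2=O)cc1` carries carboxy in place of 2-cyanoethyl on a saturated chain carbon bound to an aromatic nitrogen. Among the measured compounds shown here, no compound with carboxy has been measured yet. The evidence comes from other swaps at that place: no change at the digits printed from compound 1 to compound 2 (within the scatter), no change at the digits printed from compound 1 to compound 3 (within the scatter) and no change at the digits printed from compound 2 to compound 3 (within the scatter). With these in view, no change beyond the scatter is expected in this assay, and the expected step is no change at the digits printed from compound 3 to compound 4 (within the scatter). Compound 4 is estimated at 10000 nM, with an expected range of 6000 nM to 20000 nM.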

Compound 4, half-maximal inhibitory concentration: 10000 nM
Compound 4: the middle estimate sits on the measured number at the digits printed; measured number inside the range.
By their numbers in this assay, from the lowest: compounds 1, 2, 3 and 4 (each within the scatter of the next).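

Carboxy, the first group here to bring a hydrogen-bond donor to the saturated chain carbon bound to an aromatic nitrogen, leaves this assay flat: replacing 2-cyanoethyl gives no change at the digits printed from compound 3 to compound 4 (within the scatter), and replacing cyano gives no change at the digits printed from compound 2 to compound 4 (within the scatter). Hydrogen in place of ethyl on the ester gives no change at the digits printed from compound 1 to compound 4 (within the scatter). Nothing available accounts for this flat result. The compounds shown leave open whether an amine or a primary amide at this place would depart from this level. They also leave open whether changes elsewhere on the shared core would do so.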